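Two substituted amides and a bis(cyclopropylmethyl)amino analogue

The source may hold more compounds than are shown below. What is called first, only, known or untested is meant among the compounds shown, and "the series" means these compounds.

Compound 1 `CCCCCCC(C)Nc1ccc(NC(=O)c2cc(Cl)ccc2O)c(Cl)c1` was tested in an ADME assay on A549 cells (Homo sapiens) for cytotoxicity, read by resazurin assay, with a stated time of 48 h (on this read-out lower numbers stand for higher toxicity in this test and higher numbers for lower toxicity in this test), where compound 1 gives 23500 nM. Compound 2 `O=C(Nc1ccc(NCC2CCCC2)cc1Cl)c1cc(Cl)ccc1O` carries cyclopentylmethyl in place of 1-methylheptyl on a nitrogen on an aromatic ring, and in this assay compound 2 gives 21500 nM. The step of a 1.1-fold lower number from compound 1 to compound 2 (0.04 log units; within the scatter) shows that exchanging one alkyl group for another on that nitrogen left the read-out essentially unchanged. Among the two measured numbers, compound 1 holds the higher one, with compound 2 next at a distance inside the scatter.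

Compound 3 `O=C(Nc1ccc(N(CC2CC2)CC2CC2)cc1Cl)c1cc(Cl)ccc1O` has not been measured in this assay. It differs from compound 1 in this way: bis(cyclopropylmethyl)amino in place of (1-methylheptyl)amino on an aromatic carbon. Among the compounds with values here, the only relevant comparison is the step from compound 1 to compound 2, which altered the alkyl group on the same nitrogen without any effect beyond the scatter. On that basis the change in compound 3 is expected to produce no step beyond the scatter, a 1.1-fold lower number from compound 1 to compound 3 (0.03 log units; within the scatter). Compound 3 is therefore estimated to give 22000 nM in this assay, within a range from 10000 nM to 50000 nM.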

Compound 3, half-maximal cytotoxic concentration: 12800 nM
Estimate against measurement, compound 3: 1.7-fold (0.24 log units) above; the measured number falls inside the stated range.
By their numbers in this assay, from the lowest: compounds 3, 2 and 1 (each within the scatter of the next).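

Compound 3 extends what the earlier pair showed at this aromatic carbon: the alkyl amino group there need not keep its hydrogen on nitrogen. In this assay, bis(cyclopropylmethyl)amino, with 0 hydrogen-bond donors and 2 three-membered rings, replaces (1-methylheptyl)amino, which has 1 hydrogen-bond donor and no ring, with the same count of 9 heavy atoms, and the result is a 1.8-fold lower number from compound 1 to compound 3 (0.26 log units; within the scatter); set against the (cyclopentylmethyl)amino group, the same exchange gives a 1.7-fold lower number from compound 2 to compound 3 (0.23 log units; within the scatter), so neither step separates the three compounds in this read-out. Nothing available explains why these exchanges leave the read-out within the scatter.

The compounds shown leave open whether the same holds once the group on this aromatic carbon is no longer purely hydrocarbon on nitrogen, as with an unsubstituted amine, a morpholine ring or a chain ending in a carboxylic acid. They also leave open whether a much shorter group such as methylamino, or a phenyl ring on the nitrogen, would stay within the scatter of these three compounds.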